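Losing the 4-methoxybenzyl group from compound 1

The compounds below may be only part of what the source reports. "The series", "measured", "known", "first", "only" and "open" are said of these compounds alone.

Among the compounds with values here, in a functional assay on PC-3 cells (Homo sapiens) for inhibition, read by MTT assay, with a stated time of 48 h (on this read-out lower numbers stand for stronger inhibition and higher numbers for weaker inhibition), compound 1 (`COc1ccc(CO[C@H]2C=C[C@H]3C/C=C\C[C@H](c4ccc(F)cc4)OC(=O)C[C@@H]2O3)cc1`) gives 2230 nM, the lower of the two numbers so far, while compound 2 (`COc1ccc(CO[C@H]2C=C[C@H]3C/C=C\C[C@H](c4ccc5ccccc5c4)OC(=O)C[C@@H]2O3)cc1`) gives 45400 nM. Compound 3 (`O=C1C[C@@H]2O[C@@H](C=C[C@@H]2O)C/C=C\C[C@H](c2ccc(F)cc2)O1`) carries hydrogen in place of 4-methoxybenzyl on an oxygen on a saturated carbon. Within the data shown here, the only measured step, a 20-fold higher number from compound 1 to compound 2 (1.31 log units; beyond the scatter), puts naphthalen-2-yl in place of 4-fluorophenyl on a saturated ring carbon, so it does not touch this oxygen. Among the measured compounds shown here, it shows only that one exchange moved the number far. A moderate rise is therefore expected, an estimated 3.6-fold higher number from compound 1 to compound 3 (0.55 log units; beyond the scatter), on weak evidence. For compound 3 the expected value is 8000 nM, within an estimated range of 1500 nM to 40000 nM.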

Compound 3, half-maximal inhibitory concentration: 35800 nM
Estimate against measurement, compound 3: 4.5-fold (0.65 log units) below; measured number inside the range.
By their numbers in this assay, from the lowest: compound 1; then compounds 3 and 2 (each within the scatter of the next).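

In this assay the oxygen on the saturated carbon proves to matter: going from (4-methoxybenzyl)oxy to hydroxy gives a 16-fold higher number from compound 1 to compound 3 (1.21 log units; beyond the scatter) as a large loss of inhibition. The group on this oxygen, and not only the group on the saturated ring carbon, can therefore move the number far. No evidence at hand accounts for this loss. On these data alone, whether a plain benzyl group, a methyl ether or an acetyl ester on this oxygen would retain the inhibition stays open. So does whether hydroxy costs as much alongside naphthalen-2-yl.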